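This account rests on a few compounds, and the source may have more. Where it says the series, first, only, none or still open, it means among the compounds named here.

Among the compounds with values here, in a functional assay on A549 cells (Homo sapiens) for antiproliferative activity, read by CCK-8 assay, with a stated time of 72 h (a higher number here means a weaker inhibitor, a lower number a stronger inhibitor), compound 3 (`Nc1ccccc1NC(=O)c1ccc(COc2ccccc2)cc1`) gives 6760 nM and holds the lowest of the two actual numbers so far. In this assay compound 2 (`O=C(NO)c1ccc(COc2ccccc2)cc1`) gives 28000 nM and lies higher. Compound 1 (`Nc1ccccc1NC(=O)c1ccc(COc2ccc([N+](=O)[O-])cc2)cc1`) reads > 32000 nM in this assay and that is a limit of the assay, not a number.

Compound 4 (`Nc1cc(F)ccc1NC(=O)c1ccc(COc2ccccc2)cc1`) differs from compound 3 by fluoro in place of hydrogen on an aromatic carbon, meta to an amino group and para to a large group, so 2-aminophenyl becomes 2-amino-4-fluorophenyl; fluoro in place of hydrogen on an aromatic carbon is the whole change.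

Two measured steps lead to compound 3. The step of a 4.1-fold lower number from compound 2 to compound 3 (0.62 log units; beyond the scatter) replaces hydroxy with 2-aminophenyl on an amide-type nitrogen, and the step of an at least 4.7-fold lower number from compound 1 to compound 3 (0.67 log units; beyond the scatter) puts hydrogen in place of nitro at another place in the molecule. Neither tests fluoro at this position, so no step beyond the scatter is expected in this assay and any drift is expected to be slight.

The expected change is a 1.2-fold higher number from compound 3 to compound 4 (0.07 log units; within the scatter) and stays small. For compound 4 the estimated value is 8000 nM with an expected range from 3000 nM to 22000 nM in this estimate.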

Compound 4, half-maximal inhibitory concentration: 8340 nM
The estimate for compound 4 lay 1.0-fold (0.02 log units) below the measured number, within the range that was stated.
By their numbers in this assay, from the lowest: compounds 3 and 4 (each within the scatter of the next); then compound 2. At a limit, above all of these: compound 1.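

In this assay, fluoro in place of hydrogen, on the aromatic carbon meta to an amino group and para to a large group, gives a 1.2-fold higher number from compound 3 to compound 4 (0.09 log units; within the scatter), the first reading at this position among the compounds shown. The replacement of hydroxy on the amide-type nitrogen still shows with the fluoro in place, at a 3.4-fold lower number from compound 2 to compound 4 (0.53 log units; beyond the scatter), against a 4.1-fold lower number from compound 2 to compound 3 (0.62 log units; beyond the scatter) without it. Nothing shown gives a reason for this result.

Going by these compounds, whether this carbon would read the same with chloro, methoxy or an amine in place of fluoro stays open, as does the reading of fluoro on the other carbons of this ring. Also open, on these data alone, is how a carboxylic acid or a longer chain would read in place of the amino group.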